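A few compounds are considered here, and "the series" means these few. Any claim that something is new, unique, unknown or untested is made for them only; others in the source may bear on it.

Compound 1 `COc1cc(OC)c(-c2coc3cc(OCc4ccc(F)cc4)ccc3c2=O)cc1OC` gives 1120 nM
Compound 2 `COc1cc(OC)c(-c2coc3cc(OCc4cccc(Cl)c4)ccc3c2=O)cc1OC` gives 2280 nM
Compound 3 `COc1cc(OC)c(-c2coc3cc(OCc4cccc(Br)c4)ccc3c2=O)cc1OC` gives 4400 nM

In a functional assay on B16 cells (Mus musculus) for antiproliferative activity, read by MTT assay, with a stated time of 24 h (on this read-out lower numbers stand for stronger inhibition and higher numbers for weaker inhibition), compound 3 stands level with compound 2 (a 1.9-fold higher number from compound 2 to compound 3 (0.29 log units; within the scatter)) and clear of compound 1 (a 3.9-fold higher number from compound 1 to compound 3 (0.59 log units; beyond the scatter)). Compound 4 `COc1cc(OC)c(-c2coc3cc(OCc4ccccc4Br)ccc3c2=O)cc1OC` keeps the shared core and carries 2-bromophenyl in place of 3-bromophenyl on a saturated chain carbon bound to an oxygen on an aromatic ring. Among the compounds with values here, no measured compound carries 2-bromophenyl. The nearest guides are the modest aryl exchanges, the one not yet cited being a 2.0-fold higher number from compound 1 to compound 2 (0.31 log units; beyond the scatter) and the bromo for chloro exchange above. Going by these compounds, no step beyond the scatter is therefore expected in this assay and the direction stays open. The estimated step is small (a 1.5-fold lower number from compound 3 to compound 4 (0.17 log units; within the scatter)). Compound 4 is expected near 3000 nM with an estimated range from 1100 nM to 8000 nM.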

Compound 4, half-maximal inhibitory concentration: 8900 nM
The estimate for compound 4 lay 3.0-fold (0.47 log units) below the measured number, and the stated range ends below it.
By their numbers in this assay, from the lowest: compound 1; then compounds 2 and 3 (each within the scatter of the next); then compound 4.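

Within the data shown here, with the same atoms joined differently, 2-bromophenyl in place of 3-bromophenyl in this assay gives a 2.0-fold higher number from compound 3 to compound 4 (0.31 log units; beyond the scatter), so the bromine's place on the ring matters on its own, which the earlier steps could not separate from the identity of the halogen. Compound 4 also has the highest number of the series, with a 3.9-fold higher number from compound 2 to compound 4 (0.59 log units; beyond the scatter) and a 7.9-fold higher number from compound 1 to compound 4 (0.90 log units; beyond the scatter). No measurement at hand accounts for this shift. Going by these compounds, whether methoxy or nitrile in place of bromo would follow the same order stays open, as does the effect of a longer chain.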